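The source may hold more compounds than are shown below. What is called first, only, known or untested is meant among the compounds shown, and "the series" means these compounds.

Measured compounds:
compound 1 `N[C@@H](COP(=O)(O)OCCCOC(=O)CCc1ccccc1OCc1cccc(Cc2ccccc2)c1)C(=O)O` — 0.077
compound 2 `N[C@@H](COP(=O)(O)OCCCOC(=O)CCc1ccccc1OCc1cccc(Oc2ccc(F)cc2)c1)C(=O)O` — 0.66
compound 3 `N#Cc1ccc(Oc2cccc(COc3ccccc3CCC(=O)OCCCOP(=O)(O)OC[C@H](N)C(=O)O)c2)cc1` — 0.041

In an assay on cells for activation of probable G-protein coupled receptor 34 (Mus musculus), with a stated time of 1 h (a lower number here means a smaller maximal response, a higher number a larger maximal response), compound 3 gives 0.041, the lowest of the three numbers. Compound 1 lies close to it, a number 0.036 lower from compound 1 to compound 3 (within the scatter), so the two cannot be told apart. Compound 2 stands far above: a number 0.62 lower from compound 2 to compound 3 (beyond the scatter).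

Compound 4 `CC(C)(C)c1cccc(Oc2cccc(COc3ccccc3CCC(=O)OCCCOP(=O)(O)OC[C@H](N)C(=O)O)c2)c1` arises from compound 3 by the change (3-(tert-butyl)phenyl in place of 4-cyanophenyl on an oxygen on an aromatic ring).

For the measured compounds named here, three steps bear on this. The switch a number 0.58 higher from compound 1 to compound 2 (beyond the scatter) shows that a phenoxy group carrying fluoro can lift the response strongly, while a number 0.62 lower from compound 2 to compound 3 (beyond the scatter) shows that exchanging fluoro for cyano on that phenoxy undoes the gain entirely, leaving compound 3 no different from compound 1, as a number 0.036 lower from compound 1 to compound 3 (within the scatter) confirms. Going by the values given here, no measured pair exchanges cyano for tert-butyl, and none moves the substituent to the 3-position of the phenoxy ring, so the new compound is not covered directly. Since the 4-cyanophenyl group that accompanies the low number of compound 3 leaves, a rise is expected, but how much of the response of compound 2 is recovered is uncertain. The step a number 0.31 higher from compound 3 to compound 4 (beyond the scatter) is therefore expected to be a moderate rise, with a wide range. Compound 4 is estimated at 0.35, between 0.08 and 0.7.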

Compound 4, intrinsic activity: the largest response reached, as a fraction of the reference agonist's: 0.39
Estimate against measurement, compound 4: 0.040 below, and the stated range covers the measured number.
By their numbers in this assay, from the lowest: compounds 3 and 1 (each within the scatter of the next); then compound 4; then compound 2.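

In this assay, a sizeable response at this position, on an oxygen on an aromatic ring, does not depend on the 4-fluorophenyl group: replacing 4-cyanophenyl with 3-(tert-butyl)phenyl gives a number 0.35 higher from compound 3 to compound 4 (beyond the scatter), and replacing benzyl with 3-(tert-butyl)phenoxy on the aromatic carbon gives a number 0.31 higher from compound 1 to compound 4 (beyond the scatter). The 3-(tert-butyl)phenyl group does not match 4-fluorophenyl, however, with a number 0.27 lower from compound 2 to compound 4 (beyond the scatter), so the change separates compound 4 from compound 2 as well as from compound 1 and compound 3, which cannot be told apart from each other. The data shown offer no independent measurement that could account for these differences.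

Going by these compounds, it remains open whether the rise belongs to the tert-butyl group itself or to its 3-position on the phenyl ring, a question that 4-(tert-butyl)phenyl and 3-fluorophenyl would help to separate. Also open, on these data alone, are how 3-methoxyphenyl or 3-(dimethylamino)phenyl would stand on the same oxygen, and whether the nitrile would still go with a low response as 3-cyanophenyl.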